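From 4-bromophenyl to 3-chlorophenyl on a shared core

The source may hold more compounds than are shown below. What is called first, only, known or untested is meant among the compounds shown, and "the series" means these compounds.

Compound 1 `S=C(N/N=C/c1ccc2ccccc2n1)Nc1cccc(Br)c1`: 70000 nM
Compound 2 `S=C(N/N=C/c1ccc2ccccc2n1)Nc1ccc(Br)cc1`: 56800 nM

Within the data shown here, in a functional assay on HeLa cells (Homo sapiens) for antiproliferative activity, read by sulforhodamine B assay, with a stated time of 72 h (on this read-out higher numbers stand for weaker inhibition and lower numbers for stronger inhibition), compound 2 stands level with its only measured neighbour: a 1.2-fold lower number from compound 1 to compound 2 (0.09 log units; within the scatter). Compound 3 `S=C(N/N=C/c1ccc2ccccc2n1)Nc1cccc(Cl)c1` carries 3-chlorophenyl in place of 4-bromophenyl on an amide-type nitrogen. Among the measured compounds shown here, that single measured step bears on the change only through the ring position, and no measured compound carries chlorine. No step beyond the scatter is therefore expected in this assay. The expected step is small: a 1.1-fold higher number from compound 2 to compound 3 (0.02 log units; within the scatter). Compound 3 is estimated at 60000 nM, with an expected range of 28000 nM to 110000 nM.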

Compound 3, half-maximal inhibitory concentration: 52500 nM
Beside the measured number, compound 3's estimate is 1.1-fold (0.06 log units) above it; the range from low to high includes it.
By their numbers in this assay, from the lowest: compounds 3, 2 and 1 (each within the scatter of the next).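

In this assay, among these compounds, chlorine enters the comparison for the first time: chloro in place of bromo on an aromatic carbon (a 1.3-fold lower number from compound 1 to compound 3 (0.12 log units; within the scatter)) stays within the scatter. So does 3-chlorophenyl in place of 4-bromophenyl on the amide-type nitrogen (a 1.1-fold lower number from compound 2 to compound 3 (0.03 log units; within the scatter)), a change of both halogen and ring position. No measurement offers an explanation for these results. The compounds shown leave open whether an amine or a carboxylic acid on the phenyl ring, in place of the halogen, would give a step beyond the scatter.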